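Nitro substitution on an inactive cytotoxicity series

This account rests on a few compounds, and the source may have more. Where it says the series, first, only, none or still open, it means among the compounds named here.

Of the compounds shown here, three sharing one core have been tested in a functional assay on L1210 cells (Mus musculus) for cytotoxicity, with a stated time of 48 h; on this read-out lower numbers stand for stronger inhibition and higher numbers for weaker inhibition. Compound 1 `Clc1ccc(Cc2nn3c(Br)c(-c4ccc(Br)cc4)nc3s2)cc1` reaches only the assay limit of > 250000 nM. Compound 2 `Cc1ccc(-c2nc3sc(Cc4ccc(Cl)cc4)nn3c2Br)cc1` likewise reaches only the limit of > 250000 nM. Compound 3 `Clc1ccc(Cc2nn3c(Br)c(-c4ccccc4)nc3s2)cc1` also gives only the limit of > 250000 nM. Because every value sits at the same limit (the limit of > 250000 nM in this assay, at which 3 of the 3 values shown sit), none of the three steps can be read: the change a step that the two limits leave unreadable from compound 1 to compound 2, the change a step that the two limits leave unreadable from compound 1 to compound 3 and the change a step that the two limits leave unreadable from compound 2 to compound 3 all remain of unknown size, and compound 3 therefore stands nowhere in particular among the three, all of them being undistinguished at the ceiling of this assay.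

Compound 4 `O=[N+]([O-])c1ccc(-c2nc3sc(Cc4ccc(Cl)cc4)nn3c2Br)cc1` differs from compound 3 by nitro in place of hydrogen on an aromatic carbon. The measured steps bear on this change only in the sense that every substituent tried at that position, bromo, methyl and hydrogen, left the compound at the limit; their sizes give no direction for a nitro group. Compound 4 is thus expected to show a step of a number no higher from compound 3 to compound 4 (the limit leaves the size open) in this assay that cannot be anticipated beyond the scatter, and it is most likely to remain at the ceiling. Compound 4 is accordingly estimated at 250000 nM, within a range from 50000 nM to 1000000 nM.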

Compound 4, half-maximal inhibitory concentration: 94000 nM
Compound 4: the middle estimate sits 2.7-fold (0.42 log units) above what was measured; low and high end bracket the measured number.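

For the compounds shown here, at the place on the aromatic ring where the earlier compounds carry bromo, methyl or hydrogen, nitro is the first group to give a readable number in this assay, with an at least 2.6-fold lower number from compound 3 to compound 4 (0.42 log units; beyond the scatter). The picture is the same when nitro is set against the two other substituents, with an at least 2.6-fold lower number from compound 2 to compound 4 (0.42 log units; beyond the scatter) for nitro in place of methyl and an at least 2.6-fold lower number from compound 1 to compound 4 (0.42 log units; beyond the scatter) for nitro in place of bromo. This position therefore can change the read-out, which the earlier compounds could not show, but each step gives only a smallest possible size, because the other three compounds have no exact number of their own: the limit of > 250000 nM in this assay, at which 3 of the 4 values shown sit.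

On these data alone, whether this change is particular to nitro remains open, as does whether an amine, a carboxylic acid or a nitrile at the same place would also bring compound 3 off its limit. As far as these compounds go, it also remains open whether the step from hydrogen to nitro would keep its size if the other bromo, the one on the shared core, gave way to hydrogen.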